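A few compounds are considered here, and "the series" means these few. Any claim that something is new, unique, unknown or untested is made for them only; others in the source may bear on it.

The compounds share one core and differ only in the groups attached to it. In an in vitro ADME assay on microsomes from liver (Macaca mulatta) for metabolic stability, using NADPH, with a stated time of 10 min, tested at 0.5 uM (a higher number here means that the compound lasts longer, a lower number that the compound disappears faster), compound 3, `COc1cc(C2CCN(CC(N)=O)CC2)ccc1Nc1ncc2ccc(-c3ccccc3OC)n2n1`, gives > 0.666 h, which is a limit of the assay rather than a number, so compound 3 sits at the limit of > 0.666 h in this assay, at which 1 of the 3 values shown sits. Compound 1, `COc1cc(C2CCN(C[C@@H](C)O)CC2)ccc1Nc1ncc2ccc(-c3ccccc3N(C)S(C)(=O)=O)n2n1`, gives < 0.0834 h in this assay, again a limit and not a number. Compound 2, `COc1cc(C2CCNCC2)ccc1Nc1ncc2ccc(-c3ccccc3N(C)S(C)(=O)=O)n2n1`, gives < 0.0834 h, also a limit. Within the data shown here, the single measured step, a step that the two limits leave unreadable from compound 1 to compound 2, joins two limits and therefore cannot be sized. Compound 4, `COc1cc(C2CCN(CC(N)=O)CC2)ccc1Nc1ncc2ccc(-c3ccccc3N(C)S(C)(=O)=O)n2n1`, carries methyl(methylsulfonyl)amino in place of methoxy on an aromatic carbon. Among the measured compounds shown here, no measured step covers this change directly, but the group that enters is the one that compound 1 and compound 2 already carry. Because compound 1 and compound 2 both sit at the limit of < 0.0834 h in this assay, at which 2 of the 3 values shown sit, compound 4 is expected to move from the long-lived limit down to the short-lived side, the estimated step being an at least 11-fold lower number from compound 3 to compound 4 (1.04 log units; beyond the scatter). Compound 4 is therefore estimated at 0.06 h, with a likely range from 0.02 h to 0.2 h.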

Compound 4, half-life: < 0.0834 h
Compound 4 gave a limit, no number; the forecaster's own chance of this, stated with the estimate: 70%; the middle value does not contradict the limit.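

With the carbamoylmethyl on the ring nitrogen unchanged, putting methyl(methylsulfonyl)amino in place of methoxy on the aromatic carbon gives in this assay an at least 7.9-fold lower number from compound 3 to compound 4 (0.90 log units; beyond the scatter) and so shows that a change at this one place is enough to span the range seen here. On these data alone, compound 3 and compound 4 each stand at a limit of the assay, so the full size of this step is unknown, and the steps among compound 1, compound 2 and compound 4 cannot be read. Carbamoylmethyl on the ring nitrogen does not keep compound 4 away from the low end, where it joins compound 1 and compound 2: the limit of < 0.0834 h in this assay, at which 3 of the 4 values shown sit.

Which part of the entering group matters stays open, and a plain amine or a methylsulfonyl on that aromatic carbon would help to separate them. Also open, as far as these compounds go, is how long a methoxy compound would last with hydrogen or 2-hydroxypropyl on the ring nitrogen.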